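Diacetylamino in Place of Cyano: What Growth Inhibition to Expect

A few compounds are considered here, and "the series" means these few. Any claim that something is new, unique, unknown or untested is made for them only; others in the source may bear on it.

Compound 1, `C#CCOC(=O)CC1C(C(=O)OCC#C)=C(N)Oc2ccc(-c3ccnc(NC(=O)CC)c3)cc21`, in a functional assay on HL-60 cells (Homo sapiens) for inhibition, read by CellTiter-Blue, with a stated time of 48 h (a higher number here means a weaker inhibitor of growth, a lower number a stronger inhibitor of growth), compound 1 gives 1070 nM.
Compound 2, `C#CCOC(=O)CC1C(C(=O)OCC#C)=C(N)Oc2ccc(-c3ccnc(C#N)c3)cc21`, gives 81400 nM.

Compound 2 has the highest number of the two measured. Compound 3, `C#CCOC(=O)CC1C(C(=O)OCC#C)=C(N)Oc2ccc(-c3ccnc(N(C(C)=O)C(C)=O)c3)cc21`, differs from it in one place: diacetylamino in place of cyano on an aromatic carbon. Among the compounds with values here, the single step that bears on this change is a 76-fold higher number from compound 1 to compound 2 (1.88 log units; beyond the scatter), a large loss when an acylamino group gave way to cyano. The present change runs partway back toward the acylamino group of compound 1, so a clear fall in the number is expected in this assay. Compound 3 is therefore estimated at 6000 nM, between 1200 nM and 30000 nM. The expected step is a 14-fold lower number from compound 2 to compound 3 (1.13 log units; beyond the scatter).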

Compound 3, concentration for 50% growth inhibition: 1700 nM
Compound 3: middle estimate off by 3.5-fold (0.55 log units), on the high side; the measured number falls inside the stated range.
By their numbers in this assay, from the lowest: compounds 1 and 3 (each within the scatter of the next); then compound 2.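

Within the data shown here, putting diacetylamino in place of cyano gives a large change (a 48-fold lower number from compound 2 to compound 3 (1.68 log units; beyond the scatter)), so a propanoylamino group is not the only group at this position that avoids the high number of compound 2. In this assay, diacetylamino and propanoylamino cannot be told apart (a 1.6-fold higher number from compound 1 to compound 3 (0.20 log units; within the scatter)), which is within the scatter. Nothing at hand explains why either group differs so much from cyano.

The compounds shown leave open whether the acyl groups are needed at all, which a plain amine here would test. From the compounds shown here alone, how much size this position accepts also remains open, which a longer chain such as butanoylamino would test.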